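Tricyclic chromone series: phenyl for methyl, growth inhibition

A few compounds are considered here, and "the series" means these few. Any claim that something is new, unique, unknown or untested is made for them only; others in the source may bear on it.

Measured compounds:
compound 1 `Cc1oc2c3c(ccc2c(=O)c1C)OC[C@H]1[C@@H]3C2=C(CCCC2=O)OC1(C)C` — > 100000 nM
compound 2 `Cc1oc2c3c(ccc2c(=O)c1-c1ccccc1)OC[C@H]1[C@@H]3C2=C(CCCC2=O)OC1(C)C` — > 100000 nM
compound 3 `Cc1oc2c3c(ccc2c(=O)c1C)OC[C@H]1[C@@H]3C2=C(CC(C)(C)CC2=O)OC1(C)C` — > 100000 nM

All three values come from an ADME assay on MRC5 cells (Homo sapiens) for antiproliferative activity, read by MTT assay, with a stated time of 48 h; a lower number here means a stronger inhibitor, a higher number a weaker inhibitor. For compound 1 the value > 100000 nM is a limit of the assay, not a number. For compound 2 the value > 100000 nM is likewise a limit. For compound 3 the value > 100000 nM is again a limit. Going by the values given here, the only step that can be named is a step that the two limits leave unreadable from compound 1 to compound 2; its size is not readable, since both ends sit at the limit. The change behind it is phenyl in place of methyl on an aromatic carbon.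

Compound 4 `Cc1oc2c3c(ccc2c(=O)c1-c1ccccc1)OC[C@H]1[C@@H]3C2=C(CC(C)(C)CC2=O)OC1(C)C` is not yet measured. It differs from compound 3 by phenyl in place of methyl on an aromatic carbon, the same change as that from compound 1 to compound 2, and the surroundings of the place are described in the same words for both pairs. The difference between the core of compound 1 and the core of compound 3 is not broken down here.

What can be expected for compound 4 in this assay rests on (the limit of > 100000 nM in this assay, at which 3 of the 3 values shown sit), at which every shown value sits. For compound 4 the expected step that the limit leaves unreadable from compound 3 to compound 4 is therefore not readable as a number either, since the starting value is a limit. For compound 4 the estimate is 150000 nM, with an expected range from 50000 nM to 500000 nM, and most likely the assay again reports only a limit.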

Compound 4, half-maximal inhibitory concentration: > 100000 nM
Compound 4 ended at the assay's limit (the forecaster's own chance of this, stated with the estimate: 90%); the middle value is on the limit's open side.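

In this assay compound 4 gives > 100000 nM, a limit of the assay and not a number. No step can be read from compound 3 to compound 4, phenyl in place of methyl, as both compounds sit at the limit: the limit of > 100000 nM in this assay, at which 4 of the 4 values shown sit.

The compounds shown leave open whether that change, or the difference between the two cores, alters the read-out at all in this assay.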